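The compounds below may be only part of what the source reports. "The series", "measured", "known", "first", "only" and "open" are said of these compounds alone.

Measured compounds:
compound 1 `CC#C[C@@H](Cc1nnn[nH]1)c1ccc(OCc2ccc3scc(-c4cc(OCCOC)ccc4C)c3c2)cc1` — 0.367 h
compound 2 `CC#C[C@@H](Cc1nnn[nH]1)c1ccc(OCc2ccc3scc(C4CCCCC4)c3c2)cc1` — 0.767 h
compound 3 `CC#C[C@@H](Cc1nnn[nH]1)c1ccc(OCc2ccc3scc(-c4cncnc4C)c3c2)cc1` — 0.333 h

In an ADME assay on microsomes from liver (Rattus norvegicus) for metabolic stability (a lower number here means that the compound disappears faster, a higher number that the compound lasts longer), compound 3 gives 0.333 h, the lowest of the three numbers. Compound 1 lies within the scatter of compound 3, while compound 2 stands clearly apart, as the step of a 2.3-fold lower number from compound 2 to compound 3 (0.36 log units; beyond the scatter) shows. Compound 4 `CC#C[C@@H](Cc1nnn[nH]1)c1ccc(OCc2ccc3scc(-c4ccccc4C(F)(F)F)c3c2)cc1` has not yet been measured. It differs from compound 3 in a single place: 2-(trifluoromethyl)phenyl in place of 4-methylpyrimidin-5-yl on an aromatic carbon. Among the measured compounds shown here, two measured steps bear on this change, both exchanges of the group on that same aromatic carbon: a 1.1-fold lower number from compound 1 to compound 3 (0.04 log units; within the scatter) and the step from compound 2 already named. The two aryl groups gave numbers within the scatter of each other, and only the cyclohexyl lifted the number beyond it. For the measured compounds named here, no measured compound carries the 2-(trifluoromethyl)phenyl group, so the nearest guide is that the aryl-bearing compounds 1 and 3 gave similar numbers. The step of a 1.4-fold higher number from compound 3 to compound 4 (0.13 log units; within the scatter) is therefore expected to be small, a slight rise at most, probably within the scatter. Compound 4 is estimated at 0.45 h, with a range from 0.25 h to 0.9 h.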

Compound 4, half-life: 0.167 h
Beside the measured number, compound 4's estimate is 2.7-fold (0.43 log units) above it; measured number below the stated range.
By their numbers in this assay, from the lowest: compounds 4, 3 and 1 (each within the scatter of the next, the first and the last beyond it); then compound 2.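

In this assay the aryl groups on this aromatic carbon, two ring bonds from the ring sulfur, no longer behave as one set: the step of a 2.2-fold lower number from compound 1 to compound 4 (0.34 log units; beyond the scatter) separates two of them, while the step of a 2.0-fold lower number from compound 3 to compound 4 (0.30 log units; within the scatter) does not separate the 2-(trifluoromethyl)phenyl and 4-methylpyrimidin-5-yl groups. The step of a 4.6-fold lower number from compound 2 to compound 4 (0.66 log units; beyond the scatter) is the widest seen at this position, and compound 2 with its cyclohexyl group now stands beyond the scatter of all three aryl compounds. Nothing available explains these differences.

The compounds shown leave open whether the number of compound 2 is particular to cyclohexyl or would also hold for a cyclopentyl or piperidine ring. They also leave open how a plain phenyl group would compare with the 2-(trifluoromethyl)phenyl group on this carbon.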